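The compounds below may be only part of what the source reports. "The series", "measured", "known", "first", "only" and "open" are said of these compounds alone.

Working notes on the series. Compound 1 `COc1ccc2cc([C@H](C)c3nnc(SCc4ccc(Cl)cc4)n3-c3ccc(F)cc3)ccc2c1` in a functional assay on DU-145 cells (Homo sapiens) for cytotoxicity, read by MTT assay (a higher number here means a weaker inhibitor, a lower number a stronger inhibitor), gives 57400 nM. Compound 2 `COc1ccc2cc([C@H](C)c3nnc(SCc4ccc(Cl)cc4)n3-c3ccc(Cl)cc3)ccc2c1` gives 109000 nM, the highest of the two numbers; the step of a 1.9-fold higher number from compound 1 to compound 2 (0.28 log units; within the scatter) lies within the scatter. Compound 3 `COc1ccc2cc([C@H](C)c3nnc(SCc4c(Cl)cccc4Cl)n3-c3ccc(Cl)cc3)ccc2c1` differs from compound 2 by 2,6-dichlorophenyl in place of 4-chlorophenyl on a saturated chain carbon bound to a sulfur. For the measured compounds named here, no measured step touches that part of the structure: the one step known concerns a different ring, so it does not bear on this change, and nothing beyond the scatter is expected in either direction. Compound 3 is therefore expected at about 100000 nM, within 35000 nM to 300000 nM, meaning an expected step of a 1.1-fold lower number from compound 2 to compound 3 (0.04 log units; within the scatter).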

Compound 3, half-maximal inhibitory concentration: 36100 nM
Beside the measured number, compound 3's estimate is 2.8-fold (0.44 log units) above it, and the stated range covers the measured number.
By their numbers in this assay, from the lowest: compounds 3, 1 and 2 (each within the scatter of the next, the first and the last beyond it).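

For the compounds shown here, replacing 4-chlorophenyl with 2,6-dichlorophenyl on a saturated chain carbon bound to a sulfur gives a 3.0-fold lower number from compound 2 to compound 3 (0.48 log units; beyond the scatter) in this assay and is the first change here to move the number beyond the scatter. The earlier step, a 1.9-fold higher number from compound 1 to compound 2 (0.28 log units; within the scatter) for chloro in place of fluoro on an aromatic carbon, did not. This position therefore responds to substitution, though the compounds shown rest on this single modest step. As far as these compounds go, what an amine, a carboxylic acid or a longer chain would do on that same carbon remains open. No measurement shown gives a reason for this step.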